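This account rests on a few compounds, and the source may have more. Where it says the series, first, only, none or still open, it means among the compounds named here.

Measured so far:
compound 1, `N#Cc1c(N2CCC(c3ccc(F)cc3F)CC2)ccn(CC2CC2)c1=O`: 68 nM
compound 2, `N#Cc1c(N2CCC(c3c(F)cccc3F)CC2)ccn(CC2CC2)c1=O`: 31 nM

In a functional assay on CHO cells for positive allosteric modulation of metabotropic glutamate receptor 2 (Homo sapiens), with a stated time of 30 min (a lower number here means that less compound is needed, a higher number that more compound is needed for the effect), compound 2 stands lowest of the two numbers; its nearest neighbour is compound 1, which gives 68 nM in this assay. Going by the values given here, the one step between them, a 2.2-fold lower number from compound 1 to compound 2 (0.34 log units; beyond the scatter), is modest and reaches beyond the scatter. Compound 3, `N#Cc1c(N2CCC(c3cc(F)cc(F)c3)CC2)ccn(CC2CC2)c1=O`, has not been measured in this assay. It differs from compound 2 in one place: 3,5-difluorophenyl in place of 2,6-difluorophenyl on a saturated ring carbon. Among the compounds with values here, the only step that bears on this change is the one from compound 1 to compound 2, which likewise rearranged the two fluorines on the phenyl and gave a 2.2-fold lower number from compound 1 to compound 2 (0.34 log units; beyond the scatter). A step of comparable size is therefore expected; since compound 2 gives 31 nM and already holds the lowest number, the change is expected to run upward, as a 2.4-fold higher number from compound 2 to compound 3 (0.38 log units; beyond the scatter). Compound 3 is accordingly estimated at 75 nM in this assay, within a range of 25 nM to 230 nM.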

Compound 3, half-maximal effective concentration: 151 nM
Beside the measured number, compound 3's estimate is 2.0-fold (0.30 log units) below it, within the range that was stated.
By their numbers in this assay, from the lowest: compound 2; then compound 1; then compound 3.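

In this assay, the two fluorines on the phenyl group at this saturated ring carbon can be rearranged with the same atoms and still shift the number by a 4.9-fold higher number from compound 2 to compound 3 (0.69 log units; beyond the scatter), and the 3,5-difluorophenyl group also falls behind the 2,4-difluorophenyl group, with a 2.2-fold higher number from compound 1 to compound 3 (0.35 log units; beyond the scatter). The three compounds therefore rank by fluorine arrangement alone, and the 3,5-difluorophenyl group gives the highest number of the set, with both of its steps beyond the scatter. No evidence is available that would explain this order.

The compounds shown leave open how a phenyl group with a single fluorine, or with chlorine or a methoxy group in place of fluorine, would compare. They also do not tell whether this order would persist with a different group on the core.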